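The compounds below may be only part of what the source reports. "The series", "measured", "known", "first", "only" and "open" are said of these compounds alone.

Measured in an ADME assay on HEK293 cells (Homo sapiens) for cytotoxicity, read by MTT assay, with a stated time of 48 h; on this read-out lower numbers stand for stronger inhibition and higher numbers for weaker inhibition:
- compound 1 `CCCCCCOc1cc(NC(=O)c2cc(C(F)(F)F)cc(C(F)(F)F)c2)ccc1N(C)S(C)(=O)=O`: > 500000 nM (a limit)
- compound 2 `CN(c1ccc(NC(=O)c2cc(C(F)(F)F)cc(C(F)(F)F)c2)cc1OCc1cccc(C(F)(F)F)c1)S(=O)(=O)Cc1ccccc1`: 59800 nM
- compound 3 `CN(c1ccc(NC(=O)c2cc(C(F)(F)F)cc(C(F)(F)F)c2)cc1OCc1ccccc1C(F)(F)F)S(=O)(=O)Cc1ccccc1`: > 500000 nM (a limit)

Compound 3 stands at the limit of > 500000 nM in this assay, at which 2 of the 3 values shown sit, so it has no exact number, only a limit. Compound 4 `CCCCCCOc1cc(NC(=O)c2cc(C(F)(F)F)cc(C(F)(F)F)c2)ccc1N(C)S(=O)(=O)Cc1ccccc1` is made from compound 3 by one change: pentyl in place of 2-(trifluoromethyl)phenyl on a saturated chain carbon bound to an oxygen on an aromatic ring. Put another way, 2-(trifluoromethyl)benzyl gives way to hexyl, and the aromatic ring of that group is lost.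

Among the measured compounds shown here, only one measured step bears on this, and only loosely. It is an at least 8.3-fold higher number from compound 2 to compound 3 (0.92 log units; beyond the scatter), and it shows that a change in this part of the molecule can move the read-out clearly. That step only shifts the trifluoromethyl group on the ring, however, so it says little about replacing the ring with a chain. Hexyloxy also occurs in compound 1, whose > 500000 nM is again a limit.

Taken together, these results point to little movement, with any shift more likely toward lower numbers, since compound 3 can hardly be followed upward on this read-out. The expected change is an at least 1.6-fold lower number from compound 3 to compound 4 (0.22 log units; that floor lies within the scatter). For compound 4 the estimate is 300000 nM, with an expected range of 60000 nM to 700000 nM, and a reported limit is about as likely as a number.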

Compound 4, half-maximal inhibitory concentration: 69900 nM
Compound 4: middle estimate off by 4.3-fold (0.63 log units), on the high side; the measured number falls inside the stated range.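

In this assay, replacing 2-(trifluoromethyl)benzyl with hexyl gives an at least 7.1-fold lower number from compound 3 to compound 4 (0.85 log units; beyond the scatter) and shows that this group can be changed to a chain with no aromatic ring and still yield an exact number. The comparison with the 3-(trifluoromethyl)benzyl group gives a 1.2-fold higher number from compound 2 to compound 4 (0.07 log units; within the scatter) and places hexyl and that group level on this read-out, so at this site the outcome does not simply follow the presence or absence of an aromatic ring. With hexyloxy held fixed, phenyl in place of hydrogen on the saturated carbon bound to the sulfonyl sulfur gives an at least 7.1-fold lower number from compound 1 to compound 4 (0.85 log units; beyond the scatter), so hexyloxy alone does not settle the read-out, and the sulfonyl end of the molecule counts as well.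

As far as these compounds go, the true sizes of the two steps that start from a limit stay open: the limit of > 500000 nM in this assay, at which 2 of the 4 values shown sit. Also open, from the compounds shown here alone, is how the read-out would respond at the oxygen-bound site to a butyl or octyl chain, to an unsubstituted benzyl group, or to a chain ending in an amine or a carboxylic acid.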